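Diaryl urea series: removing the chloro from compound 3

The compounds below may be only part of what the source reports. "The series", "measured", "known", "first", "only" and "open" are said of these compounds alone.

Compound 3 `CCN(CC)CCn1cnnc1-c1cc(Oc2ccc(NC(=O)Nc3ccc(Cl)c(C(F)(F)F)c3)cc2F)ccn1` gives 850 nM in a functional assay on NCI-H460 cells (Homo sapiens) for antiproliferative activity, read by MTT assay, with a stated time of 72 h (a higher number here means a weaker inhibitor, a lower number a stronger inhibitor), the lowest of the three numbers obtained so far. Compound 2 `Cn1cnnc1-c1cc(Oc2ccc(NC(=O)Nc3cccc(C(F)(F)F)c3)cc2F)ccn1` gives 1270 nM in this assay, a gap from compound 3 that lies within the scatter, so no order between the two can be read. Within the data shown here, compound 1 `Cn1ncnc1-c1cc(Oc2ccc(NC(=O)Nc3cccc(C(F)(F)F)c3)cc2F)ccn1` gives 11600 nM, and the only single-point step measured, a 9.1-fold lower number from compound 1 to compound 2 (0.96 log units; beyond the scatter), concerns the triazole on the shared core, not the urea aryl.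

Compound 4 `CCN(CC)CCn1cnnc1-c1cc(Oc2ccc(NC(=O)Nc3cccc(C(F)(F)F)c3)cc2F)ccn1` differs from compound 3 by hydrogen in place of chloro on an aromatic carbon, on the carbon ortho to the trifluoromethyl group and para to the large group. Among the measured compounds shown here, no measured pair isolates this change; compound 2 and compound 3 differ at the same place but also at the triazole substituent, so their values only bracket the region. The expected step of a 1.8-fold higher number from compound 3 to compound 4 (0.25 log units; within the scatter) is therefore small, with a modest shift toward a higher number. Compound 4 is estimated at 1500 nM, within 600 nM to 4000 nM.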

Compound 4, half-maximal inhibitory concentration: 9870 nM
The estimate for compound 4 lay 6.6-fold (0.82 log units) below the measured number; measured number above the stated range.
By their numbers in this assay, from the lowest: compounds 3 and 2 (each within the scatter of the next); then compounds 4 and 1 (each within the scatter of the next).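

In this assay, the chloro ortho to a trifluoromethyl group and para to a large group proves to matter on this scaffold, with a 12-fold higher number from compound 3 to compound 4 (1.06 log units; beyond the scatter) when nothing else changes. With the 3-(trifluoromethyl)phenyl urea held constant, the (diethylamino)methyl extension on the chain carbon bound to an aromatic nitrogen gives a 7.8-fold higher number from compound 2 to compound 4 (0.89 log units; beyond the scatter), so it does not help on this aryl, while a 1.2-fold lower number from compound 1 to compound 4 (0.07 log units; within the scatter) leaves compound 1 and compound 4 without an order. No measurement here gives a cause for either step beyond the scatter.

Still open, on these data alone, is whether the chloro step carries over to the methyl-substituted triazole of compound 2, and whether fluoro, bromo or methoxy on the same carbon would behave as chloro does. Also open, as far as these compounds go, is how a dimethylamino or morpholine chain end would compare with diethylamino.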